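A few compounds are considered here, and "the series" means these few. Any claim that something is new, unique, unknown or untested is made for them only; others in the source may bear on it.

Measured compounds in an assay on microsomes from brain for inhibition of Fatty-acid amide hydrolase 1 (Rattus norvegicus), read by fluorescence and HPLC, with a stated time of 60 min; on this read-out higher numbers stand for weaker inhibition and lower numbers for stronger inhibition:
- compound 1, `CC(Oc1ccc(Oc2ccc(C(F)(F)F)cc2)cc1)C(=O)Cn1nnc(-c2ccc(Cl)cc2)n1`, gives 300 nM
- compound 2, `CCCCCCCCc1ccc(OC(C)C(=O)Cn2nnc(-c3ccc(C(=O)OC)cc3)n2)cc1`, gives 25 nM
- compound 3, `COC(=O)c1ccc(-c2nnn(CC(=O)C(C)Oc3ccc(Oc4ccc(F)cc4)cc3)n2)cc1`, gives 36 nM

Compound 3 stands second highest of the three numbers. Among the measured compounds shown here, its nearest neighbour is compound 2, and the one measured step, a 1.4-fold higher number from compound 2 to compound 3 (0.16 log units; within the scatter), lies within the scatter, so the two cannot be ordered. Compound 1 is the furthest from compound 3, with a number well beyond the scatter higher.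

The next compound, compound 4, `COC(=O)c1ccc(-c2nnn(CC(=O)C(C)Oc3ccc(Oc4ccc(C(F)(F)F)cc4)cc3)n2)cc1`, carries the change (trifluoromethyl in place of fluoro on an aromatic carbon). For the measured compounds named here, no measured pair isolates this change. Compound 1 does carry the trifluoromethyl on the same phenoxy ring, but it also differs from compound 3 on the other aromatic ring, so its value against that of compound 3 can only be noted, not assigned to either difference. Going by the values given here, the only measured step, from octyl to 4-fluorophenoxy, was within the scatter, which suggests that this end of the molecule tolerates changes without large shifts in this assay.

For compound 4 the expected step is a 1.5-fold higher number from compound 3 to compound 4 (0.18 log units; within the scatter), that is, no change beyond the scatter, with a slight lean toward a higher number. The estimate for compound 4 in this assay is 55 nM, within a range of 20 nM to 160 nM.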

Compound 4, half-maximal inhibitory concentration: 130 nM
The estimate for compound 4 lay 2.4-fold (0.37 log units) below the measured number; the range from low to high includes it.
By their numbers in this assay, from the lowest: compounds 2 and 3 (each within the scatter of the next); then compound 4; then compound 1.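

In this assay, among the compounds shown here, trifluoromethyl in place of fluoro on an aromatic carbon gives a 3.6-fold higher number from compound 3 to compound 4 (0.56 log units; beyond the scatter) and is the first change at this end of the molecule to exceed the scatter, so this position is not as tolerant as the octyl to 4-fluorophenoxy step suggested. The para substituent on the phenoxy ring decides how the replacement of octyl reads: a 1.4-fold higher number from compound 2 to compound 3 (0.16 log units; within the scatter) stays within the scatter, while 4-(trifluoromethyl)phenoxy in place of octyl gives a 5.2-fold higher number from compound 2 to compound 4 (0.72 log units; beyond the scatter) and is a real shift toward weaker inhibition. With the 4-(trifluoromethyl)phenoxy group held constant, methoxycarbonyl in place of chloro gives a 2.3-fold lower number from compound 1 to compound 4 (0.36 log units; beyond the scatter) as a separate effect, showing that the other aromatic ring also moves the number in this assay.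

Methyl, methoxy or nitrile at the same place on the phenoxy ring, and a carboxylic acid or amide in place of the methoxycarbonyl, would show how far each of these two trends extends. No measurement here gives a reason for the shift caused by the trifluoromethyl group.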